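The source may report more compounds than this note shows. Statements on the series, on what has been measured and on what is new or still open speak of the compounds shown alone.

Of the compounds shown here, three have been measured in a functional assay on HO8910 cells (Homo sapiens) for inhibition, read by MTT assay, with a stated time of 24 h, tested at 1 ug/mL; a higher number here means more inhibition of growth at the concentration tested, a lower number less inhibition of growth. There, compound 1 (`O=C(CCCCC1CCSS1)Nc1ccc(Cl)cn1`) gives 2.1%, compound 2 (`O=C(CCCCC(CCSC(=O)c1ccccc1)SC(=O)c1ccccc1)Nc1ccccc1`) gives 3.79%, and compound 3 (`O=C(CCCCC(CCSC(=O)c1ccccc1)SC(=O)c1ccccc1)Nc1ccccc1Cl`) gives 2.35%. Compound 3 lies within the scatter of both other compounds, so this assay does not separate it from either.

Compound 4 (`O=C(CCCCC(CCSC(=O)c1ccccc1)SC(=O)c1ccccc1)Nc1ccc(Cl)cc1`) has not yet been measured. It has the same atoms as compound 3, joined differently: 4-chlorophenyl in place of 2-chlorophenyl on an amide-type nitrogen. In words, 4-chlorophenyl stands in place of 2-chlorophenyl on an amide-type nitrogen.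

For the measured compounds named here, only one measured step bears on this change. The step that brings in the 2-chlorophenyl group gave a number 1.4 percentage points lower from compound 2 to compound 3 (within the scatter). Going by the values given here, no measured compound carries 4-chlorophenyl on an amide-type nitrogen, so the data hold no direct step for it. With that single step inside the scatter, no step beyond the scatter is expected in this assay, and no direction can be favoured with any confidence.

The expected outcome is a number 1.2 percentage points higher from compound 3 to compound 4 (within the scatter). Compound 4 is estimated at 3.5%, with an expected range from 0.5% to 11%.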

Compound 4, percent growth inhibition at one concentration: 1.29%
Beside the measured number, compound 4's estimate is 2.2 percentage points above it, within the range that was stated.
By their numbers in this assay, from the lowest: compounds 4, 1, 3 and 2 (each within the scatter of the next).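

In this assay, putting 4-chlorophenyl in place of 2-chlorophenyl on an amide-type nitrogen gives a number 1.1 percentage points lower from compound 3 to compound 4 (within the scatter), so this read-out does not tell the two placements of the chloro apart. Chloro in place of hydrogen on an aromatic carbon now has two readings, a number 1.4 percentage points lower from compound 2 to compound 3 (within the scatter) and a number 2.5 percentage points lower from compound 2 to compound 4 (within the scatter), and neither separates a chlorophenyl compound from compound 2, the compound without chloro. No other measurement is available that could account for these numbers.

Going by these compounds, whether a different group on this ring, such as an amine or a carboxylic acid in place of the chloro, or a longer chain between the amide and the sulfur-bearing carbon, would give a step beyond the scatter remains open. On these data alone, since every step among compounds 2, 3 and 4 lies within the scatter at the single concentration tested, it also remains open whether the place of the chloro matters under conditions where growth is inhibited to a greater degree.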